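Swapping the Amide Substituent on a Shared Thiazole-Free Core

A few compounds are considered here, and "the series" means these few. Any claim that something is new, unique, unknown or untested is made for them only; others in the source may bear on it.

Measured so far:
compound 1, `CC(=O)N1CCc2nc(C#Cc3ccccc3)sc2C1`: > 10000 nM
compound 2, `O=C(C1CC12CCC2)N1CCc2nc(C#Cc3ccccc3)sc2C1`: 3.9 nM
compound 3, `COC1CC(C(=O)N2CCc3nc(C#Cc4ccccc4)sc3C2)C1`: 640 nM

All three compounds share one core and differ only in the group on the carbonyl carbon. In an assay on HEK293 cells for positive allosteric modulation of metabotropic glutamate receptor 5 (Homo sapiens), read by FLIPR, with a stated time of 1 h (a lower number here means that less compound is needed, a higher number that more compound is needed for the effect), compound 1 reaches only a limit, > 10000 nM, and this is described by the limit of > 10000 nM in this assay, at which 1 of the 3 values shown sits. Among the two real numbers, compound 3 gives the higher one, and its nearest neighbour is compound 2, separated by a 160-fold higher number from compound 2 to compound 3 (2.22 log units; beyond the scatter). Compound 4, `O=C(C1CCC(F)(F)CC1)N1CCc2nc(C#Cc3ccccc3)sc2C1`, has not yet been measured. It differs from compound 3 by 4,4-difluorocyclohexyl in place of 3-methoxycyclobutyl on a carbonyl carbon.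

Every change at this carbonyl carbon has moved the number strongly: an at least 2500-fold lower number from compound 1 to compound 2 (3.40 log units; beyond the scatter), an at least 15-fold lower number from compound 1 to compound 3 (1.19 log units; beyond the scatter) and a 160-fold higher number from compound 2 to compound 3 (2.22 log units; beyond the scatter) all lie far beyond the scatter. Compound 2, the one carrying a ring-only carbon group, gives the lowest number of the set, while the methyl of compound 1 gives only a limit. The new group of compound 4 is again a carbon ring without an acceptor, so a step toward lower numbers than compound 3 is expected, though not necessarily to the level of compound 2. The expected step is an 8.0-fold lower number from compound 3 to compound 4 (0.90 log units; beyond the scatter). Compound 4 is therefore estimated at 80 nM, within a range from 10 nM to 600 nM.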

Compound 4, half-maximal effective concentration: 70 nM
Estimate against measurement, compound 4: 1.1-fold (0.06 log units) above, and the stated range covers the measured number.
By their numbers in this assay, from the lowest: compound 2; then compound 4; then compound 3. At a limit, above all of these: compound 1.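

In this assay, 4,4-difluorocyclohexyl in place of 3-methoxycyclobutyl on the carbonyl carbon gives a 9.1-fold lower number from compound 3 to compound 4 (0.96 log units; beyond the scatter), while an 18-fold higher number from compound 2 to compound 4 (1.25 log units; beyond the scatter) shows that this six-membered ring, with its two fluorine atoms, still does not match the group of compound 2. A ring this large is thus accepted at this position, and the comparison with the smallest group shown, methyl, gives an at least 140-fold lower number from compound 1 to compound 4 (2.15 log units; beyond the scatter). That last step has only one firm end, as compound 1 gives a limit and not a real number: the limit of > 10000 nM in this assay, at which 1 of the 4 values shown sits.

The step from compound 3 to compound 4 changes the ring size, removes the oxygen and adds fluorine all at once, so the compounds shown cannot say which of these changes accounts for the lower number. Plain cyclohexyl would separate ring size from the fluorine atoms, and a cyclohexyl ring carrying a methoxy group or an amine would show whether the six-membered ring keeps its number with such a group attached.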